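Triazole nitrogen substituent swap in the chromene series

The source may hold more compounds than are shown below. What is called first, only, known or untested is meant among the compounds shown, and "the series" means these compounds.

Among the compounds with values here, compound 1 `CCOC(=O)C1=Cc2ccccc2OC1(OCc1cn(CC(=O)Nc2ccc(C)cc2)nn1)C(F)(F)F` is measured in a functional assay on HeLa cells (Homo sapiens) for inhibition, read by MTT assay, with a stated time of 24 h (a lower number here means a stronger inhibitor, a higher number a weaker inhibitor), where compound 1 gives 67400 nM, the only number among the values shown. Compound 2 `CCOC(=O)C1=Cc2ccccc2OC1(OCc1cc(-c2ccc3ccccc3c2)no1)C(F)(F)F` reaches only a limit of this assay in > 150000 nM. Compound 3 `CCOC(=O)C1=Cc2ccccc2OC1(OCc1cc(-c2ccc(OC)cc2)no1)C(F)(F)F` likewise reaches only a limit in > 150000 nM. The change a step that the two limits leave unreadable from compound 2 to compound 3 is therefore unreadable; two of the three values sit at the limit of > 150000 nM in this assay, at which 2 of the 3 values shown sit.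

Compound 4 `CCOC(=O)C1=Cc2ccccc2OC1(OCc1cn(-c2cccc(C(F)(F)F)c2)nn1)C(F)(F)F` differs from compound 1 in one place: 3-(trifluoromethyl)phenyl in place of ((4-methylphenyl)carbamoyl)methyl on an aromatic nitrogen. Within the data shown here, no measured step touches this position, since the only readable pair, compounds 2 and 3, varies a different ring. The expectation for compound 4 thus rests on compound 1 alone, with no reason drawn from the shown steps to expect movement beyond the scatter in this assay. Compound 4 is estimated at 80000 nM, with a range from 25000 nM to 150000 nM. The expected step of a 1.2-fold higher number from compound 1 to compound 4 (0.07 log units; within the scatter) is small, and a limit rather than a number is a real possibility.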

Compound 4, half-maximal inhibitory concentration: > 150000 nM
Compound 4: a limit, no number; the forecaster's own chance of this, stated with the estimate: 35%; middle value at least 1.8-fold (0.27 log units) away from the limit.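

Compound 4 reaches only a limit in this assay, at > 150000 nM. Within the data shown here, this gives the first readable step at this aromatic nitrogen: 3-(trifluoromethyl)phenyl in place of ((4-methylphenyl)carbamoyl)methyl brings an at least 2.2-fold higher number from compound 1 to compound 4 (0.34 log units; beyond the scatter), a change beyond the scatter whose full size the limit leaves unfixed. Compound 1 remains the only compound shown with a number, and the rest of the set gathers at one limit: the limit of > 150000 nM in this assay, at which 3 of the 4 values shown sit.

The change replaces the whole group at once, leaving the parts played by the carbonyl, the amide hydrogen and the 4-methylphenyl ring unseparated. On these data alone, whether a carboxylic acid or a longer chain ending in an amine on this nitrogen would read stronger than compound 1 remains open, and the step between compound 2 and compound 3 stays unreadable.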